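A Dimethylphenyl Swap Tested Against Lung Cancer Cells

The source may report more compounds than this note shows. Statements on the series, on what has been measured and on what is new or still open speak of the compounds shown alone.

In a functional assay on A549 cells (Homo sapiens) for antiproliferative activity, read by MTT assay, with a stated time of 48 h (on this read-out higher numbers stand for weaker inhibition and lower numbers for stronger inhibition), compound 2 `N#CC1=C(N)Oc2c(c3nc4ccccc4nc3c3ccccc23)C12C(=O)N(Cc1cnnn1-c1cccc(Cl)c1)c1ccccc12` gives 32600 nM. This is the lowest of the three numbers in hand, but it stands within the scatter of compound 1 `Cc1cccc(-n2nncc2CN2C(=O)C3(C(C#N)=C(N)Oc4c3c3nc5ccccc5nc3c3ccccc43)c3ccccc32)c1`, which gives 39600 nM, and of compound 3 `N#CC1=C(N)Oc2c(c3nc4ccccc4nc3c3ccccc23)C12C(=O)N(Cc1cnnn1-c1cccc(S(N)(=O)=O)c1)c1ccccc12`, which gives 44200 nM. Compound 4 `Cc1cc(C)cc(-n2nncc2CN2C(=O)C3(C(C#N)=C(N)Oc4c3c3nc5ccccc5nc3c3ccccc43)c3ccccc32)c1` has not yet been measured. It differs from compound 2 in one place: 3,5-dimethylphenyl in place of 3-chlorophenyl on an aromatic nitrogen. The steps already measured all concern substituents on this same phenyl ring: a 1.2-fold lower number from compound 1 to compound 2 (0.08 log units; within the scatter), a 1.1-fold higher number from compound 1 to compound 3 (0.05 log units; within the scatter) and a 1.4-fold higher number from compound 2 to compound 3 (0.13 log units; within the scatter). None of them moves this assay beyond the scatter, whether the ring carries methyl, chloro or sulfamoyl, so the phenyl substituent has so far made no difference that can be trusted. The exchange to 3,5-dimethylphenyl is therefore expected to leave this assay essentially unchanged, and compound 4 is estimated at 36000 nM, with a range from 16000 nM to 80000 nM. This estimate is expected to amount to a 1.1-fold higher number from compound 2 to compound 4 (0.04 log units; within the scatter), a step no larger than the scatter.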

Compound 4, half-maximal inhibitory concentration: > 50000 nM
Compound 4 gave a limit, no number; the forecaster's own chance of this, stated with the estimate: 5%; middle value at least 1.3-fold (0.14 log units) from the limit.
By their numbers in this assay, from the lowest: compounds 2, 1 and 3 (each within the scatter of the next). At a limit, above all of these: compound 4.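

In this assay compound 4 gives > 50000 nM, which is a limit of the assay and not a number. The steps to it are an at least 1.5-fold higher number from compound 2 to compound 4 (0.18 log units; that floor lies within the scatter), an at least 1.1-fold higher number from compound 3 to compound 4 (0.05 log units; that floor lies within the scatter) and an at least 1.2-fold higher number from compound 1 to compound 4 (0.10 log units; that floor lies within the scatter), so each floor stays within the scatter, and the extra methyl on the phenyl ring is shown neither to shift the read-out nor to leave it unchanged. Where methyl, chloro and sulfamoyl on this ring all gave numbers, 3,5-dimethylphenyl on the aromatic nitrogen is the first group here to end at a limit, which leaves the size of this change open upward: the limit of > 50000 nM in this assay, at which 1 of the 4 values shown sits.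

The compounds shown leave open whether compound 4 truly lies beyond the scatter of the other three. They also leave open how an amine or a carboxylic acid on this phenyl ring would read.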